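The source may report more compounds than this note shows. Statements on the series, on what has been measured and on what is new or still open speak of the compounds shown alone.

compound 1 (`CCCCC1C(C(=O)OC)=C(C)NC(C)=C1C(=O)OC`) gives "not active" (no number reported)
compound 2 (`COC(=O)C1=C(C)NC(C)=C(C(=O)OC)C1c1ccc(C)cc1`) gives 500000 nM

Within the data shown here, in a functional assay on MDA-MB cells (Homo sapiens) for cytotoxicity, read by MTT assay, with a stated time of 48 h (a higher number here means a weaker inhibitor, a lower number a stronger inhibitor), compound 2 is the only compound with a number (500000 nM) and no measured step is available to scale from. Compound 3 (`COC(=O)C1=C(C)NC(C)=C(C(=O)OC)C1c1ccc(Cl)cc1`) has chloro in place of methyl on an aromatic carbon, para to a large group (chloro in place of methyl on an aromatic carbon). Among the measured compounds shown here, the single number gives little guidance, so in this assay only a small expected step toward stronger inhibition (a 1.7-fold lower number from compound 2 to compound 3 (0.22 log units; within the scatter)) is assumed, possibly no larger than the scatter. For compound 3 the estimated value is 300000 nM with an expected range (80000 nM to 1000000 nM).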

Compound 3, half-maximal inhibitory concentration: 460000 nM
Beside the measured number, compound 3's estimate is 1.5-fold (0.19 log units) below it; measured number inside the range.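

In this assay, among these compounds, replacing 4-methylphenyl with 4-chlorophenyl gives a 1.1-fold lower number from compound 2 to compound 3 (0.04 log units; within the scatter) and provides the first measured step. At this aromatic carbon, para to a large group, chloro and methyl therefore cannot be told apart by this read-out. No available evidence bears on this result.

Going by these compounds, it remains open whether an amine, a carboxylic acid or a methoxy group at this position would give a step beyond the scatter. Replacing the methyl esters on the shared core with an amide is also untested in the compounds shown here.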